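The source may report more compounds than this note shows. Statements on the series, on what has been measured and on what is new or still open speak of the compounds shown alone.

In an in vitro ADME assay on microsomes from liver (Homo sapiens) for pharmacokinetics, read by LC-MS, with a stated time of 10 min, tested at 1 uM (on this read-out higher numbers stand for fast clearance and lower numbers for slow clearance), compound 1 `CN1C[C@H](C(=O)Nc2ccc(F)cc2)[C@@H](c2ccc(/C=C/C(=O)Nc3ccccc3N)cc2)C1` gives 5 mL/min/kg, compound 2 `CN1C[C@H](C(=O)Nc2ccc(Br)cc2)[C@@H](c2ccc(/C=C/C(=O)Nc3ccccc3N)cc2)C1` gives 3 mL/min/kg and compound 3 `CN1C[C@H](C(=O)Nc2cccc(F)c2)[C@@H](c2ccc(/C=C/C(=O)Nc3ccccc3N)cc2)C1` gives 6 mL/min/kg. Compound 3 therefore stands within the scatter of both other compounds. Compound 4 `CN1C[C@H](C(=O)Nc2ccc(F)c(Cl)c2)[C@@H](c2ccc(/C=C/C(=O)Nc3ccccc3N)cc2)C1` carries 3-chloro-4-fluorophenyl in place of 3-fluorophenyl on an amide-type nitrogen. Bearing on this change are a 1.2-fold higher number from compound 1 to compound 3 (0.08 log units; within the scatter) and a 2.0-fold higher number from compound 2 to compound 3 (0.30 log units; within the scatter), both on that same nitrogen, and a 1.7-fold lower number from compound 1 to compound 2 (0.22 log units; within the scatter), a bromo for fluoro exchange. Within the data shown here, all three lie within the scatter, and no measured compound carries the 3-chloro-4-fluorophenyl group. In this assay, as far as these compounds go, no step beyond the scatter is expected, and the direction stays open. The expected step is a 1.5-fold lower number from compound 3 to compound 4 (0.18 log units; within the scatter). For compound 4 the estimate is 4 mL/min/kg, with a range of 2 mL/min/kg to 9 mL/min/kg.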

Compound 4, clearance: 15 mL/min/kg
Compound 4: middle estimate off by 3.8-fold (0.57 log units), on the low side; measured number outside the range, above it.
By their numbers in this assay, from the lowest: compounds 2, 1 and 3 (each within the scatter of the next); then compound 4.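

Among these compounds, in (this assay) the aryl group on the amide-type nitrogen moves clearance beyond the scatter for the first time (a 2.5-fold higher number from compound 3 to compound 4 (0.40 log units; beyond the scatter)), so this position is less flat than compounds 1, 2 and 3 suggested. Chloro in place of hydrogen on an aromatic carbon gives the one-place step (a 3.0-fold higher number from compound 1 to compound 4 (0.48 log units; beyond the scatter)), and the 4-bromophenyl comparison gives the widest gap (a 5.0-fold higher number from compound 2 to compound 4 (0.70 log units; beyond the scatter)). No measured evidence accounts for this rise.

Still open, as far as these compounds go, is whether 3-chlorophenyl without the fluoro gives the same step. Also open, from the compounds shown here alone, is how an amine or a carboxylic acid on this ring would read.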